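This account rests on a few compounds, and the source may have more. Where it says the series, first, only, none or still open, it means among the compounds named here.

The compounds with a measurement are:
Compound 1, `Cc1ccccc1-c1nc(CN2CCC(C(=O)NCCCN3CCCCC3)CC2)c(C)o1`. In an ADME assay on microsomes from liver (Rattus norvegicus) for metabolic stability, read by LC-MS, using NADPH, at 37 degrees C (a lower number here means that the compound disappears faster, a higher number that the compound lasts longer), compound 1 gives > 0.5 h, which is a limit of the assay rather than a number.
Compound 2, `Cc1oc(-c2c(F)cccc2F)nc1CN1CCC(C(=O)NCCCN2C[C@H](C)C[C@H](C)C2)CC1`. In this assay compound 2 gives 0.35 h.
Compound 3, `CC[C@@H]1C[C@H](CC)CN(CCCNC(=O)C2CCN(Cc3nc(-c4c(F)cccc4F)oc3C)CC2)C1`. In this assay compound 3 gives 0.065 h.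

Among the two actual numbers, compound 2 stands highest. Among the measured compounds shown here, its nearest neighbour is compound 3, and the only measured step, a 5.4-fold lower number from compound 2 to compound 3 (0.73 log units; beyond the scatter), exchanges one saturated ring for another on the chain. For the measured compounds named here, the value of compound 1 is only a limit of > 0.5 h in this assay, at which 1 of the 3 values shown sits, and offers no step to compare against.

Compound 4, `COc1cccc(F)c1-c1nc(CN2CCC(C(=O)NCCCN3C[C@H](C)C[C@H](C)C3)CC2)c(C)o1`, is not yet measured. It differs from compound 2 in one place: methoxy in place of fluoro on an aromatic carbon. Going by the values given here, this change is on the aromatic ring, whereas the one measured step was made on a saturated chain carbon, so that step does not bear on it directly. Among the compounds with values here, no measured pair here alters the aromatic ring at all. With nothing to point either way, the expectation is a step of no clear direction and within the scatter, a 1.2-fold lower number from compound 2 to compound 4 (0.07 log units; within the scatter). Compound 4 is therefore estimated at 0.3 h, with a range from 0.12 h to 0.7 h.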

Compound 4, half-life: 0.143 h
Compound 4: the middle estimate sits 2.1-fold (0.32 log units) above what was measured, within the range that was stated.
By their numbers in this assay, from the lowest: compound 3; then compound 4; then compound 2. At a limit, above all of these: compound 1.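

In this assay the aromatic ring proves not to be a neutral place, since exchanging one fluoro for methoxy, which turns 2,6-difluorophenyl into 2-fluoro-6-methoxyphenyl, gives a 2.4-fold lower number from compound 2 to compound 4 (0.39 log units; beyond the scatter) and so shortens the half-life by more than the usual scatter. Among the compounds shown here, the only earlier step, a 5.4-fold lower number from compound 2 to compound 3 (0.73 log units; beyond the scatter), came from a change on a saturated chain carbon, so this is the first sign that a change on an aromatic carbon can also make a compound of this series disappear faster. Nothing shown here explains why this swap shortens the half-life.

On these data alone, how a chloro, a methyl or a nitrile on this same aromatic carbon would compare with fluoro and methoxy stays open, as does the effect of replacing the remaining fluoro as well, which would give a 2,6-dimethoxyphenyl ring. As far as these compounds go, it is also open whether the methoxy step would look the same in a compound carrying the 3,5-diethylpiperidin-1-yl group of compound 3 in place of 3,5-dimethylpiperidin-1-yl.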